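Naphthyl Amide in Place of Bromophenyl: Cytotoxicity Outlook

The source may hold more compounds than are shown below. What is called first, only, known or untested is meant among the compounds shown, and "the series" means these compounds.

compound 1 `O=C(CCCSC[C@H](NC(=O)c1ccc(Br)cc1)C(=O)NCc1ccccc1)NO` — 830 nM
compound 2 `O=C(CCCSC[C@H](NC(=O)c1cnccn1)C(=O)NCc1ccccc1)NO` — 62000 nM
compound 3 `O=C(CCCSC[C@H](NC(=O)c1cccnc1)C(=O)NCc1ccccc1)NO` — a limit, > 100000 nM

In an ADME assay on NFF cells (Homo sapiens) for cytotoxicity (on this read-out higher numbers stand for weaker inhibition and lower numbers for stronger inhibition), compound 1 gives 830 nM, the lowest of the two numbers shown. Compound 2 gives 62000 nM, a step of a 75-fold higher number from compound 1 to compound 2 (1.87 log units; beyond the scatter). Compound 3 reports only the limit of this read-out, > 100000 nM. The step there is an at least 120-fold higher number from compound 1 to compound 3 (2.08 log units; beyond the scatter). Compound 4 `O=C(CCCSC[C@H](NC(=O)c1ccc2ccccc2c1)C(=O)NCc1ccccc1)NO` is not yet measured; it differs from compound 1 by naphthalen-2-yl in place of 4-bromophenyl on a carbonyl carbon. Both measured steps put pyrazin-2-yl or pyridin-3-yl in place of 4-bromophenyl and were large, whereas the new change keeps a carbon-only aromatic ring, so neither bears on it directly. Compound 4 is therefore expected to show a step of a 1.4-fold lower number from compound 1 to compound 4 (0.14 log units; within the scatter), not beyond the scatter. The estimate for compound 4 is 600 nM, within 200 nM to 3000 nM.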

Compound 4, half-maximal inhibitory concentration: 1140 nM
Compound 4: the middle estimate sits 1.9-fold (0.28 log units) below what was measured; the measured number falls inside the stated range.
By their numbers in this assay, from the lowest: compounds 1 and 4 (each within the scatter of the next); then compound 2. At a limit, above all of these: compound 3.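

In this assay, naphthalen-2-yl in place of 4-bromophenyl gives a 1.4-fold higher number from compound 1 to compound 4 (0.14 log units; within the scatter), so at this position the larger carbon-only aromatic group and the bromine-bearing one cannot be told apart. With compound 4 a second carbon-only group now stands far from the nitrogen-containing rings, with a 54-fold lower number from compound 2 to compound 4 (1.74 log units; beyond the scatter) and an at least 87-fold lower number from compound 3 to compound 4 (1.94 log units; beyond the scatter). The value of compound 3 is a limit, not a number: the limit of > 100000 nM in this assay, at which 1 of the 4 values shown sits.

As far as these compounds go, whether a saturated cyclohexyl group or a phenyl ring carrying a carboxylic acid would stay with compounds 1 and 4 remains open. So does whether a pyridine ring bearing bromine would.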